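Flipping Two Ring Stereocentres in a Weak Inhibitor

A few compounds are considered here, and "the series" means these few. Any claim that something is new, unique, unknown or untested is made for them only; others in the source may bear on it.

Within the data shown here, compound 2 `C=C1CC[C@H]2[C@](C)(CO)CCC[C@]2(C)[C@H]1C[C@]12O[C@H]1[C@@H](O)C(CO)=CC2=O` stands highest of the two numbers measured so far in a functional assay on HepG2 cells (Homo sapiens) for inhibition, read by MTT assay, with a stated time of 72 h (a higher number here means a weaker inhibitor, a lower number a stronger inhibitor), where compound 2 gives 48500 nM. Among the measured compounds shown here, its only measured neighbour is compound 1 `C=C1CC[C@H]2[C@](C)(CO)CCC[C@]2(C)[C@H]1C[C@]12O[C@H]1[C@@H](O)C(CO)=C(Cl)C2=O`, which in this assay gives 15200 nM. For the measured compounds named here, the single step known, a 3.2-fold higher number from compound 1 to compound 2 (0.50 log units; beyond the scatter), concerns hydrogen in place of chloro on a double-bonded ring carbon. Compound 3 `C=C1CC[C@H]2[C@](C)(CO)CCC[C@]2(C)[C@H]1C[C@@]12O[C@@H]1[C@@H](O)C(CO)=CC2=O` has not yet been measured. It differs from compound 2 in this way: the two compounds have the same atoms and bonds and differ only in configuration as drawn: 2 of 7 stereo elements differ; a stereocentre at a saturated ring carbon is drawn S in compound 2 and R in compound 3; a stereocentre at a saturated ring carbon is drawn S in compound 2 and R in compound 3. Going by the values given here, no measured step bears on a change of configuration alone; the one step available swaps atoms rather than turning a centre, so it gives no guide to how the mirrored arrangement at two saturated ring carbons will read. With nothing pointing in either direction, the expectation for compound 3 is a step of no particular size, no change at the digits printed from compound 2 to compound 3 (within the scatter), which is expected to lie within the scatter, although such isomer pairs can in practice differ widely. Compound 3 is therefore estimated to give about 48500 nM in this assay, within a range from 15000 nM to 150000 nM.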

Compound 3, half-maximal inhibitory concentration: 34200 nM
Compound 3: middle estimate off by 1.4-fold (0.15 log units), on the high side; the measured number falls inside the stated range.
By their numbers in this assay, from the lowest: compound 1; then compounds 3 and 2 (each within the scatter of the next).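

In this assay, turning both saturated ring carbons from S to R gives a 1.4-fold lower number from compound 2 to compound 3 (0.15 log units; within the scatter), so this first test of configuration alone does not separate the two isomers. The pair tests configuration without any other structural change getting in the way: the fact that compounds 2 and 3 differ only in the configuration as drawn. Among the steps shown, the only one that reads beyond the scatter is still the exchange of chloro for hydrogen on the double-bonded ring carbon, a 3.2-fold higher number from compound 1 to compound 2 (0.50 log units; beyond the scatter), so in these three compounds that atom counts for more than the drawn configuration at the two ring carbons.

On these data alone, because the two centres were turned together, the effect of turning each one alone remains open, as does whether the same pair of centres would read alike with chloro rather than hydrogen on the double-bonded ring carbon. Also open, as far as these compounds go, is how that carbon would respond to a group larger or different in kind from chloro and hydrogen, such as an amine or a carboxylic acid.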